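Microsomal stability of the sulfonyl series: distal ring exchange

The compounds below may be only part of what the source reports. "The series", "measured", "known", "first", "only" and "open" are said of these compounds alone.

Compound 1 `CCCCc1nc(=O)c(S(=O)(=O)c2ccc(-c3ccc(F)cc3)cc2)c(O)n1-c1c(OC)cccc1OC` and compound 2 `CCCCc1nc(=O)c(S(=O)(=O)c2ccc(-n3ccccc3=O)cc2)c(O)n1-c1c(OC)cccc1OC` share one core and differ only in the ring attached to the sulfonyl-bearing aromatic ring. In an ADME assay on microsomes from liver (Homo sapiens) for metabolic stability, using NADPH, with a stated time of 10 min (on this read-out lower numbers stand for a less stable compound and higher numbers for a more stable compound), compound 1 gives 100%, and compound 2 gives 87%. Among the measured compounds shown here, the one step known here, a number 13 percentage points lower from compound 1 to compound 2 (beyond the scatter), shows that exchanging an all-carbon aromatic ring for a heteroaromatic ring at this position lowered the read-out modestly. Compound 3 `CCCCc1[nH]c(=O)c(S(=O)(=O)c2ccc(-c3ccc(F)cc3)cc2)c(O)c1-c1c(OC)cccc1OC` has a different core, and in this assay compound 3 gives "not determined" (no result reported), so no number stands for it. Compound 4 `CCCCc1[nH]c(=O)c(S(=O)(=O)c2ccc(-c3cccnc3OC)cc2)c(O)c1-c1c(OC)cccc1OC` differs from compound 3 by 2-methoxypyridin-3-yl in place of 4-fluorophenyl on an aromatic carbon. For the measured compounds named here, only the step from compound 1 to compound 2 bears on this change, and it was a modest drop beyond the scatter for a ring-for-ring exchange at the same position on a related core; compound 3 itself offers no anchor. Compound 4 is therefore expected to show a fairly high but not complete remaining fraction, estimated at 80%, within a range of 50% to 100%.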

Compound 4, percent of the compound remaining: 72%
Estimate against measurement, compound 4: 8 percentage points above, and the stated range covers the measured number.
By their numbers in this assay, from the lowest: compound 4; then compound 2; then compound 1.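

No step can be read from compound 3 to compound 4, as compound 3 has no number in this assay. The compounds shown leave open how 2-methoxypyridin-3-yl in place of 4-fluorophenyl changes the read-out on this core. Nothing available explains the value of compound 4.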